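The source may report more compounds than this note shows. Statements on the series, on what has been measured and on what is new or still open speak of the compounds shown alone.

Within the data shown here, compound 1 `Cc1ccccc1OCC(C)O` stands lowest of the two numbers so far: in a physicochemical assay for lipophilicity, measured as octanol-water partition (a lower number here means a more polar compound, a higher number a more lipophilic compound), compound 1 gives 2.14. Among the measured compounds shown here, the only other measured member, compound 2 `Cc1cccc(Cl)c1OCC(C)O`, gives 2.73 in this assay, and the step between them is a number 0.59 log units higher from compound 1 to compound 2 (beyond the scatter), a chloro in place of hydrogen on an aromatic carbon.

Compound 3 `Cc1cc(Cl)ccc1OCC(C)O` is not yet measured. Relative to compound 1 it carries chloro in place of hydrogen on an aromatic carbon

For the measured compounds named here, the single measured step that bears on this change is the one from compound 1 to compound 2, a number 0.59 log units higher from compound 1 to compound 2 (beyond the scatter), which is the same kind of change on the same ring. A step of comparable size, upward and beyond the scatter, is therefore expected from compound 1 to compound 3 in this assay, namely a number 0.71 log units higher from compound 1 to compound 3 (beyond the scatter). For compound 3 the estimate in this assay is 2.85, expected to fall between 2.55 and 3.15.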

Compound 3, partition coefficient: 2.84
For compound 3 the middle estimate is 0.01 log units above the measured one, and the stated range covers the measured number.
By their numbers in this assay, from the lowest: compound 1; then compounds 2 and 3 (each within the scatter of the next).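

In this assay, chloro on the aromatic carbon meta to a methyl group and para to a group of 5 heavy atoms gives a number 0.70 log units higher from compound 1 to compound 3 (beyond the scatter) as a second upward step, alongside a number 0.59 log units higher from compound 1 to compound 2 (beyond the scatter) for the chloro placement in compound 2. Compounds 2 and 3 lie within the scatter of each other, so these two chloro placements on the core of compound 1 are not told apart by this read-out. Nothing measured here accounts for the size of either step.

On these data alone, whether the same position gives a similar step with a group other than chloro, such as an amine or a carboxylic acid, remains open. As far as these compounds go, it is also open whether a second chloro on the same core would add a further step.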